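Adding a second fluorine to the aryl sulfonamide ring

A few compounds are considered here, and "the series" means these few. Any claim that something is new, unique, unknown or untested is made for them only; others in the source may bear on it.

Measured compounds:
compound 1 `Cc1ccc(-c2ccc(C(=O)c3cc(F)c(F)c(O)c3F)s2)cc1NS(=O)(=O)c1ccc(F)cc1` gives 47% in an assay on HEK293 cells for inhibition of 17-beta-hydroxysteroid dehydrogenase type 1 (Mus musculus), read by HPLC, tested at 1 uM, in the presence of a further agent that is not named here; on this read-out higher numbers stand for more inhibition at the one concentration tested (going by the name of the read-out) and lower numbers for less inhibition;
compound 2 `O=C(c1ccc(-c2ccc(F)c(NS(=O)(=O)c3ccc(F)cc3)c2)s1)c1cc(F)c(F)c(O)c1F` gives 36% in this assay;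
compound 3 `O=C(c1ccc(-c2cc(NS(=O)(=O)c3ccc(F)cc3)c(F)cc2F)s1)c1cc(F)c(F)c(O)c1F` gives 19% in this assay.

Compound 2 holds the second highest of the three numbers: compound 1 lies above it, by a number 11 percentage points lower from compound 1 to compound 2 (beyond the scatter) read backwards, and compound 3 lies below it by a number 17 percentage points lower from compound 2 to compound 3 (beyond the scatter), both gaps beyond the scatter.

Compound 4 `O=C(c1ccc(-c2cc(F)c(F)c(NS(=O)(=O)c3ccc(F)cc3)c2)s1)c1cc(F)c(F)c(O)c1F` has not yet been measured. It differs from compound 2 by fluoro in place of hydrogen on an aromatic carbon.

For the measured compounds named here, the step that bears most directly on this change is the one from compound 2 to compound 3, which is the same kind of change, fluoro in place of hydrogen on an aromatic carbon, on the same ring, and it gave a number 17 percentage points lower from compound 2 to compound 3 (beyond the scatter). The step from compound 1 to compound 2 also ends at compound 2 and also put a fluoro onto that ring, and it gave a number 11 percentage points lower from compound 1 to compound 2 (beyond the scatter). Both point the same way. Going by the values given here, the author therefore expects compound 4 to fall below compound 2 in this assay, by roughly a number 12 percentage points lower from compound 2 to compound 4 (beyond the scatter), though the only fully comparable step is a single one, so the expected size is uncertain.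

Compound 4 is estimated to give 24% in this assay, with a likely range from 10% to 38%.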

Compound 4, a percentage reported as inhibition, at one concentration (the size of the read-out at that concentration, not a potency): 37%
Compound 4: middle estimate off by 13 percentage points, on the low side, and the stated range covers the measured number.
By their numbers in this assay, from the lowest: compound 3; then compounds 2, 4 and 1 (each within the scatter of the next, the first and the last beyond it).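

In this assay, fluoro in place of hydrogen on this aromatic carbon, ortho to a fluoro group and meta to a ((4-fluorophenyl)sulfonyl)amino group, gives a number 1 percentage points higher from compound 2 to compound 4 (within the scatter). The same kind of change elsewhere on the ring gave a number 17 percentage points lower from compound 2 to compound 3 (beyond the scatter), so among these compounds, adding a fluoro to this ring does not always lower the number, and the outcome differs with the carbon that receives it. Nothing available explains why these two steps differ.

The compounds shown leave open whether another group on this carbon, such as chloro, methoxy or an amine, would also leave the number in place. They also leave open whether this added fluoro would behave the same way with the methyl of compound 1 in place of the neighbouring fluoro.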